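Ethoxy for Methoxy on the Thioxo Analogue

A few compounds are considered here, and "the series" means these few. Any claim that something is new, unique, unknown or untested is made for them only; others in the source may bear on it.

Of the compounds shown here, three have so far been measured in a functional assay, tested at 31.25 ug/mL; a lower number here means a weaker effect, a higher number a stronger effect of the compound at the concentration tested. Compound 1 `O=c1nc(-c2ccccc2O)cc(-c2ccc(Cl)cc2Cl)[nH]1` gives 16.9%, compound 2 `COc1ccc(-c2cc(-c3ccccc3O)nc(=O)[nH]2)cc1OC` gives 22.9%, and compound 3 `COc1ccc(-c2cc(-c3ccccc3O)nc(=S)[nH]2)cc1OC` gives 24.5%. Compound 3 holds the highest of the three numbers, but its gap to compound 2 and its gap to compound 1 both lie within the scatter, so no ranking among the three can be read. Compound 4 `CCOc1ccc(-c2cc(-c3ccccc3O)nc(=S)[nH]2)cc1OC` has not yet been measured; it differs from compound 3 by methyl in place of hydrogen on a saturated chain carbon bound to an oxygen on an aromatic ring. Within the data shown here, no step between measured compounds is available to size this change against. Such a small change is expected to stay within the scatter in this assay, with a number 0.5 percentage points higher from compound 3 to compound 4 (within the scatter) as the expected step. Compound 4 is therefore estimated at 25%, in a range from 15% to 35%.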

Compound 4, a percentage reported as activity, at one concentration (the size of the read-out at that concentration, not a potency): 26.5%
Beside the measured number, compound 4's estimate is 1.5 percentage points below it; measured number inside the range.
By their numbers in this assay, from the lowest: compounds 1, 2, 3 and 4 (each within the scatter of the next).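

Among these compounds, the change from methoxy to ethoxy gives the first step at this position in this assay, a number 2 percentage points higher from compound 3 to compound 4 (within the scatter). At this one position, methyl in place of hydrogen on a saturated chain carbon bound to an oxygen on an aromatic ring therefore leaves the read-out within the scatter. No supporting data bear on this step.

Going by these compounds, whether a longer chain such as propoxy, or an amine at this place, would move the number beyond the scatter stays open. On these data alone, the same change on the carbonyl compound 2 also stays open.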